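This account rests on a few compounds, and the source may have more. Where it says the series, first, only, none or still open, it means among the compounds named here.

Compound 1 `O=C1NC(=S)S/C1=C\c1c[nH]c2ccccc12`: > 50000 nM
Compound 2 `O=C1NC(=O)/C(=C/c2c[nH]c3ccccc23)S1`: 1930 nM

Both compounds were tested in a functional assay on T47D cells (Homo sapiens) for cytotoxicity, read by MTT assay, with a stated time of 72 h; a higher number here means a weaker inhibitor, a lower number a stronger inhibitor. For compound 1 the result is only a limit, > 50000 nM, so where it truly stands is not known as a number. This is the limit at which one of the two values sits (the limit of > 50000 nM in this assay, at which 1 of the 2 values shown sits). Compound 2, by contrast, gives a measured number in this assay, namely 1930 nM. Going by the values given here, no step between these two compounds is worked out here, so only the bare values can be compared: one compound at the limit, the other with a number.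

The next compound, compound 3 `O=C1NC(=S)S/C1=C\c1c[nH]c2ccc(Br)cc12`, is not yet measured. It differs from compound 1 in one place: bromo in place of hydrogen on an aromatic carbon. Since compound 1 stands at a limit, no measured step from it can guide the expectation, and a change of a single heavy atom gives no reason to expect a large move. The step from compound 1 to compound 3 is therefore expected to be small, an at least 1.2-fold lower number from compound 1 to compound 3 (0.09 log units; that floor lies within the scatter). For compound 3 the estimate in this assay is 40000 nM, with a range from 8000 nM to 150000 nM.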

Compound 3, half-maximal inhibitory concentration: 11700 nM
Compound 3: the middle estimate sits 3.4-fold (0.53 log units) above what was measured; the measured number falls inside the stated range.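

Going by these compounds alone, putting a bromo in place of hydrogen on an aromatic carbon of the six-membered ring, para to a fused ring, gives the first measured step: in this assay, the change produces an at least 4.2-fold lower number from compound 1 to compound 3 (0.63 log units; beyond the scatter). The result for compound 1 is a limit and not a number, so only the smallest possible size of this step is known, and the true step could be larger: the limit of > 50000 nM in this assay, at which 1 of the 3 values shown sits. Even so, this carbon is clearly not indifferent to what it carries, since one heavy atom placed there moves the number beyond the usual scatter and gives compound 3 a measured value where compound 1 has none.

Hydrogen and bromo are the only two groups shown at this place, so it stays open whether a chloro, a methoxy group, an amine or a carboxylic acid on the same carbon would shift the number in the same direction, or by a similar amount. On these data alone, it also stays open whether bromo would produce a comparable step on another carbon of that ring, or on the core of compound 2.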